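A few compounds are considered here, and "the series" means these few. Any claim that something is new, unique, unknown or untested is made for them only; others in the source may bear on it.

Compound 3 `COc1ccc(C2N=C(SCc3cccc(Cl)c3)NC(C)=C2C(=O)Nc2ccc(Br)cc2)cc1` gives 27.3% in a functional assay on the whole organism (artery, strain albino) with Rattus norvegicus as the target, with a stated time of 180 min, at a dose of 10 mg/kg by the oral route (on this read-out higher numbers stand for more inhibition at the one dose given (going by the name of the read-out) and lower numbers for less inhibition), the highest of the three numbers measured. Compound 1 `CC1=C(C(=O)Nc2ccc(Br)cc2)C(c2ccc(Cl)cc2Cl)N=C(SCc2ccc(Cl)cc2)N1` gives 23.2%, which lies within the scatter of compound 3, while compound 2 `COc1ccc(C2N=C(SCc3ccccc3Cl)NC(C)=C2C(=O)Nc2ccc(Br)cc2)cc1` gives 11.3%, beyond the scatter below it. The step of a number 16 percentage points higher from compound 2 to compound 3 (beyond the scatter) is the only measured one that touches the same place, and it moved the read-out modestly upward.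

Compound 4 `COc1ccc(C2N=C(SCc3ccc(Cl)cc3)NC(C)=C2C(=O)Nc2ccc(Br)cc2)cc1` differs from compound 3 by 4-chlorophenyl in place of 3-chlorophenyl on a saturated chain carbon bound to a sulfur. Within the data shown here, no measured pair traces this exact change. Compound 1 also carries a (4-chlorobenzyl)sulfanyl group but differs from compound 4 elsewhere, so its value can only hint that such a group is compatible with a number near that of compound 3. Among the measured compounds shown here, the only relevant step, a number 16 percentage points higher from compound 2 to compound 3 (beyond the scatter), concerns the 2-chlorophenyl to 3-chlorophenyl move, not the move to 4-chlorophenyl. Compound 4 is therefore expected to land close to compound 3, with a step of a number 3.3 percentage points lower from compound 3 to compound 4 (within the scatter) that stays within the scatter. The estimate for compound 4 is 24%, with a range from 10% to 38%.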

Compound 4, a percentage reported as inhibition, in the whole organism at one dose (the size of the read-out at that dose, not a potency): 22.7%
Estimate against measurement, compound 4: 1.3 percentage points above; the measured number falls inside the stated range.
By their numbers in this assay, from the lowest: compound 2; then compounds 4, 1 and 3 (each within the scatter of the next).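

In this assay, the step of a number 4.6 percentage points lower from compound 3 to compound 4 (within the scatter) shows that 3-chlorophenyl and 4-chlorophenyl on a saturated chain carbon bound to a sulfur cannot be told apart on this read-out. The step of a number 11.4 percentage points higher from compound 2 to compound 4 (beyond the scatter) adds a second comparison against 2-chlorophenyl, so among these three compounds with the shared core, compound 2 stands apart from both others. With (4-chlorobenzyl)sulfanyl now held constant, the step of a number 0.5 percentage points lower from compound 1 to compound 4 (within the scatter) shows that 4-methoxyphenyl in place of 2,4-dichlorophenyl on a saturated ring carbon makes no difference beyond the scatter.

Nothing available explains why 2-chlorophenyl stands apart from the other two groups. From the compounds shown here alone, it also remains open whether an unsubstituted benzyl, a 3,4-dichlorobenzyl or a longer chain ending in an amine on the sulfur would keep the number at this level.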